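From a trifluoromethyl benzyl amide to a phenyl amide

The source may report more compounds than this note shows. Statements on the series, on what has been measured and on what is new or still open speak of the compounds shown alone.

Compound 1 `N[C@H]1CC[C@H](Nc2c(C(=O)NCc3ccco3)nc(Br)c3cccnc23)CC1` value 10000 nM
Compound 2 `CN(C)c1ccc(CNC(=O)c2nc(Br)c3cccnc3c2N[C@H]2CC[C@H](N)CC2)cc1` value "not determined" (no result reported)
Compound 3 `N[C@H]1CC[C@H](Nc2c(C(=O)NCc3cccc(C(F)(F)F)c3)nc(Br)c3cccnc23)CC1` value "not determined" (no result reported)

Within the data shown here, in a functional assay on SK-BR-3 cells (Homo sapiens) for cytotoxicity, read by MTT assay, with a stated time of 72 h (a higher number here means a weaker inhibitor, a lower number a stronger inhibitor), compound 1 gives 10000 nM and is the only one of the three compounds with a number. Compound 3 has no result reported, and compound 2 shares that position, so compound 3 cannot be ranked against compound 1 on the numbers available.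

Compound 4 `N[C@H]1CC[C@H](Nc2c(C(=O)Nc3ccccc3)nc(Br)c3cccnc23)CC1` has not yet been measured and keeps the shared core of compound 3. The change is phenyl in place of 3-(trifluoromethyl)benzyl on an amide-type nitrogen at a single place, with phenyl in place of 3-(trifluoromethyl)benzyl on an amide-type nitrogen.

Among the measured compounds shown here, no measured step in this small set shows what such a change does, and compound 3 offers no starting value. The expectation in this assay is therefore for no step beyond the scatter, in either direction, and this remains a weakly supported guess. Compound 4 is expected to stay in the same broad range as compound 1, because compound 1 gives 10000 nM as the only anchor available. For compound 4 the estimated value is 7000 nM as a central figure, with an expected range from 2000 nM to 25000 nM in this assay.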

Compound 4, half-maximal inhibitory concentration: 2000 nM
Compound 4: the middle estimate sits 3.5-fold (0.54 log units) above what was measured; measured number inside the range.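

In this assay the group on the amide-type nitrogen now has its first readable effect: phenyl in place of (furan-2-yl)methyl gives a 5.0-fold lower number from compound 1 to compound 4 (0.70 log units; beyond the scatter), with the rest of the structure unchanged. This shows that a change at this single place can move the cytotoxicity number beyond the scatter, which a single anchor value could not show. From the compounds shown here alone, neither compound 2 nor compound 3 has a reported result, so steps involving them cannot be read, and the effect of replacing 3-(trifluoromethyl)benzyl with phenyl remains unknown. No measured evidence here accounts for the step from the furan-bearing group to phenyl.

The compounds shown leave open whether the lower number goes with phenyl itself or with the removal of the furan ring, a question that a plain benzyl group on the same amide-type nitrogen would help to separate. They also leave open how a phenyl group carrying a methoxy group, a fluorine atom or an amine would compare with compound 4 at this place.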